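Amine swap on the side chain of a weak series

The source may hold more compounds than are shown below. What is called first, only, known or untested is meant among the compounds shown, and "the series" means these compounds.

Measured in a functional assay on DU-145 cells (Homo sapiens) for antiproliferative activity, read by MTT assay, with a stated time of 72 h; on this read-out higher numbers stand for weaker inhibition and lower numbers for stronger inhibition:
compound 1 `COc1cc2c(Nc3ccc(C#N)cc3)ncnc2cc1OCCCN(C)Cc1ccccc1`: > 100000 nM (a limit)
compound 2 `COc1cc2c(Nc3ccc(C#N)cc3)ncnc2cc1OCCCN1CCCCC1CCO`: > 100000 nM (a limit)
compound 3 `CCOC(=O)C1CCN(CCCOc2cc3ncnc(Nc4ccc(C#N)cc4)c3cc2OC)CC1`: 52300 nM

Among the compounds with values here, compound 3 gives the only actual number in this assay. The other two values stand at the limit of > 100000 nM in this assay, at which 2 of the 3 values shown sit.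

Compound 4 `COc1cc2c(Nc3ccc(C#N)cc3)ncnc2cc1OCCCN1CCN(C)CC1` keeps the core of compound 3 and changes only the terminal amine: 4-methylpiperazin-1-yl in place of 4-(ethoxycarbonyl)piperidin-1-yl on a saturated chain carbon, three bonds along the chain from an oxygen on an aromatic ring. The change sits on a saturated chain carbon, three bonds along the chain from an oxygen on an aromatic ring.

Measured steps at this same place are an at least 1.9-fold lower number from compound 1 to compound 3 (0.28 log units; that floor lies within the scatter) and an at least 1.9-fold lower number from compound 2 to compound 3 (0.28 log units; that floor lies within the scatter). Each is only a floor, and each lies within the scatter. The remaining step is a step that the two limits leave unreadable from compound 1 to compound 2. None of the three involves 4-methylpiperazin-1-yl, and none gives a direction for this change.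

The expected result is therefore no step beyond the scatter, anchored on compound 3 at 52300 nM. The estimated step is a 1.1-fold higher number from compound 3 to compound 4 (0.06 log units; within the scatter). For compound 4 the estimate is 60000 nM, with an expected range of 20000 nM to 120000 nM.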

Compound 4, half-maximal inhibitory concentration: 46500 nM
For compound 4 the middle estimate is 1.3-fold (0.11 log units) above the measured one; the measured number falls inside the stated range.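

In this assay, 4-methylpiperazin-1-yl and 4-(ethoxycarbonyl)piperidin-1-yl are not separated at this place, with a 1.1-fold lower number from compound 3 to compound 4 (0.05 log units; within the scatter), so a second terminal amine on the saturated chain carbon now gives an actual number. Within the data shown here, compound 4 also supplies the first steps beyond the scatter at this place: an at least 2.1-fold lower number from compound 2 to compound 4 (0.33 log units; beyond the scatter) and an at least 2.1-fold lower number from compound 1 to compound 4 (0.33 log units; beyond the scatter). Both of these steps are floors only, because their starting compounds sit at a limit: the limit of > 100000 nM in this assay, at which 2 of the 4 values shown sit.

The step between compound 1 and compound 2 cannot be read. On these data alone, whether morpholin-4-yl, 4-carboxypiperidin-1-yl or a longer chain carrying 4-methylpiperazin-1-yl would separate from compound 3 and compound 4 remains open.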